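The compounds below may be only part of what the source reports. "The series", "measured", "known", "first", "only" and "open" are said of these compounds alone.

Within the data shown here, compound 1 `COc1cc(C)nc2n/c(=N/C(=O)c3c(-c4ccc(Cl)cc4Cl)noc3C)sn12` is one of three compounds measured in a functional assay on the whole organism (strain L.) for inhibition, with Echinochloa crus-galli as the target, with a stated time of 72 h, tested at 100 mg/L (on this read-out lower numbers stand for less inhibition of growth and higher numbers for more inhibition of growth at the one concentration tested), and in it compound 1 gives 80.5%. Compound 3 `COc1cc(OC)n2s/c(=N\C(=O)c3c(-c4ccc(Cl)cc4Cl)noc3C)nc2n1` gives 85.6% in this assay, and compound 2 `Cc1cc(Cl)nc(NC(=S)NC(=O)c2c(-c3ccc(Cl)cc3Cl)noc2C)n1` gives 48.7%. Compound 1 thus sits within the scatter of compound 3 and beyond the scatter of compound 2, whose number is lower. Among the measured compounds shown here, the only measured step that changes a single place is the one from compound 1 to compound 3, a number 5.1 percentage points higher from compound 1 to compound 3 (within the scatter), a methoxy entering for a methyl on an aromatic carbon; compound 2 differs from both in more than one place, so only its value can be compared.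

Compound 4 `CSc1cc(C)nc2n/c(=N/C(=O)c3c(-c4ccc(Cl)cc4Cl)noc3C)sn12` differs from compound 1 by methylsulfanyl in place of methoxy on an aromatic carbon. For the measured compounds named here, no measured step exchanges a methoxy for a methylsulfanyl, so the step from compound 1 to compound 3 is the nearest guide: a small group swapped at this position, with the number staying within the scatter. Compound 4 is therefore expected to stay close to compound 1, with an expected step of a number 2.5 percentage points lower from compound 1 to compound 4 (within the scatter) that does not go beyond the scatter. The estimate for compound 4 in this assay is 78%, with a range from 64% to 90%.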

Compound 4, percent growth inhibition at one concentration: 75.4%
Compound 4: middle estimate off by 2.6 percentage points, on the high side, within the range that was stated.
By their numbers in this assay, from the lowest: compound 2; then compounds 4, 1 and 3 (each within the scatter of the next, the first and the last beyond it).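

In this assay, the change of methoxy to methylsulfanyl on the aromatic carbon next to the ring nitrogen gives a number 5.1 percentage points lower from compound 1 to compound 4 (within the scatter). Among these compounds, the earlier single-place step had replaced the methyl group on another carbon of the ring, so this is the first reading of a change at the carbon that carries the methoxy, and it shows that sulfur can stand in place of oxygen in this small group without the number moving beyond the scatter. Nothing available bears on why the number stays within the scatter with this change.

The methoxy and the methylsulfanyl each count 2 heavy atoms, so the compounds shown say nothing about what a group of another size or kind would do at this carbon, such as an amine, a chlorine atom or a longer chain like butoxy. Among the compounds shown here, they also leave open whether a group at this carbon can ever move the number beyond the scatter, since this is the only step seen here at this position.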